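The compounds below may be only part of what the source reports. "The series", "measured", "known", "first", "only" and "open" are said of these compounds alone.

Of the compounds shown here, three built on one shared core have been measured in a functional assay (muscle tissue) with Rattus norvegicus as the target; on this read-out higher numbers stand for an effect only at larger amounts of compound and lower numbers for an effect already at smaller amounts. Compound 1 `CNC(=O)C1=CC(C)(C)Oc2ccc([N+](=O)[O-])cc21` gives 10.7 nM. Compound 2 `CCCNC(=O)C1=CC(C)(C)Oc2ccc([N+](=O)[O-])cc21` gives 5.75 nM, and compound 3 `C#CCNC(=O)C1=CC(C)(C)Oc2ccc([N+](=O)[O-])cc21` gives 7.94 nM. Compound 2 stands at the low end of these three numbers, but the separation is slight: a 1.9-fold lower number from compound 1 to compound 2 (0.27 log units; within the scatter), a 1.3-fold lower number from compound 1 to compound 3 (0.13 log units; within the scatter) and a 1.4-fold higher number from compound 2 to compound 3 (0.14 log units; within the scatter). Each of these steps alters only the group carried on a saturated chain carbon bound to the amide-type nitrogen, and none of them moves the read-out beyond the scatter.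

Compound 4 `CC1(C)C=C(C(N)=O)c2cc([N+](=O)[O-])ccc2O1` has not yet been measured. Compared with compound 2 the change is hydrogen in place of propyl on an amide-type nitrogen. This differs in kind from the measured steps: those swapped one group for another on a chain carbon, whereas here the whole propyl chain is removed and only hydrogen remains on the nitrogen. Among the measured compounds shown here, no measured step covers that removal. The measured steps all stay within the scatter. On that basis compound 4 is expected to give a number in this assay close to that of compound 2, estimated at 8 nM with a range from 3 nM to 25 nM. From the compounds shown here alone, the implied step, a 1.4-fold higher number from compound 2 to compound 4 (0.14 log units; within the scatter), is expected to be no larger than the scatter, with a wider range than the measured steps because the removal of the chain is untested.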

Compound 4, half-maximal effective concentration: 363 nM
For compound 4 the middle estimate is 45-fold (1.66 log units) below the measured one; measured number above the stated range.
By their numbers in this assay, from the lowest: compounds 2, 3 and 1 (each within the scatter of the next); then compound 4.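

The amide-type nitrogen is far from indifferent in this assay: exchanging methyl, propyl and propargyl there left the numbers within the scatter of one another, yet leaving only hydrogen gives a 63-fold higher number from compound 2 to compound 4 (1.80 log units; beyond the scatter), together with a 46-fold higher number from compound 3 to compound 4 (1.66 log units; beyond the scatter) and a 34-fold higher number from compound 1 to compound 4 (1.53 log units; beyond the scatter). Even methyl, the smallest group among these compounds, stays with propyl and propargyl rather than with hydrogen, so across these four compounds the sharp divide lies between having a carbon group on the nitrogen and having none, and no compound shown goes against this. Nothing measured here explains why the removal has so large an effect on the read-out.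

The compounds shown leave open whether a longer chain such as butyl or hexyl, a ring such as cyclopropyl or phenyl, or a second methyl on the same nitrogen would keep the number with those of compound 1, compound 2 and compound 3. They also leave open whether a hydroxyl or methoxy group on that nitrogen would behave like the carbon groups or like hydrogen.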